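Reading Across From Compound 3 to Compound 4

This account rests on a few compounds, and the source may have more. Where it says the series, first, only, none or still open, it means among the compounds named here.

The compounds share one core, seen in compound 1 `O=c1c2cnn(-c3ccc(F)cc3)c2ncn1CC1(O)CCN(Cc2cccc(Cl)c2)CC1`, for which an assay on Sf21 cells for inhibition of ubiquitin carboxyl-terminal hydrolase 7 (Homo sapiens), read by spectrophotometry, with stated times of 30 min and 2 h (a higher number here means a weaker inhibitor, a lower number a stronger inhibitor), reports "not determined" (no result reported). Compound 2 `COC(=O)c1ccc(CN2CCC(O)(Cn3cnc4c(cnn4-c4ccc(F)cc4)c3=O)CC2)cc1` in this assay gives 4500 nM. Compound 3 `O=c1c2cnn(-c3ccc(F)cc3)c2ncn1CC1(O)CCN(Cc2c(Cl)cccc2Cl)CC1` also stands without a number in this assay, where compound 3 is recorded as "not determined" (no result reported), so it cannot be placed on the scale, and compound 1 is the further entry without one. The change from compound 3 to compound 4 `COC(=O)c1ccc(CN2CCC(O)(Cn3cnc4c(cnn4-c4ccc(F)cc4)c3=O)CC2)c(Cl)c1` is 2-chloro-4-(methoxycarbonyl)phenyl in place of 2,6-dichlorophenyl on a saturated chain carbon bound to an amine nitrogen in a ring. Among the compounds with values here, with no value for compound 3, no step can be sized from it; compound 4 is instead read beside compound 2, and no movement beyond the scatter of this assay is expected. Compound 4 is estimated at 3500 nM, within 900 nM to 14000 nM, because compound 2 gives 4500 nM.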

Compound 4, half-maximal inhibitory concentration: 800 nM
The estimate for compound 4 lay 4.4-fold (0.64 log units) above the measured number; measured number outside the range, below it.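

In this assay, chloro in place of hydrogen on an aromatic carbon gives a 5.6-fold lower number from compound 2 to compound 4 (0.75 log units; beyond the scatter), so a single added chloro on this benzyl group, with the methoxycarbonyl kept, moves the number beyond the scatter. The step from compound 3 to compound 4 cannot be read, and compound 3 still has no number. Nothing shown accounts for this gain. The compounds shown leave open whether fluoro or methyl could replace this chloro. They also leave open whether a carboxylic acid or an amide could replace the methoxycarbonyl and keep the lower number.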